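A few compounds are considered here, and "the series" means these few. Any claim that something is new, unique, unknown or untested is made for them only; others in the source may bear on it.

Measured in a functional assay on HCT-116 cells (Homo sapiens) for cytotoxicity, read by scintillation counting and thymidine incorporation, with a stated time of 72 h (a higher number here means a weaker inhibitor, a lower number a stronger inhibitor), so far:
- Compound 1 `C#CC=C(c1cc(OC)cc(OC)c1)c1ccc(OC)c(OC)c1` gives > 10000 nM, which is a limit of the assay and not a number.
- Compound 2 `COc1cc(OC)cc(C(=CC#N)c2ccc(OC)c(NC(C)=O)c2)c1` gives 92 nM in the same test.
- Compound 3 `CCOc1cc(C(=CC#N)c2cccc(OC)c2)ccc1OC` gives 450 nM in the same test.

Compound 1 has no numerical value and stands at the limit of > 10000 nM in this assay, at which 1 of the 3 values shown sits, on this scale.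

The step under review leads to compound 4 `COc1cc(OC)cc(C(=CCCN(C)C)c2ccc(OC)c(OC)c2)c1`, with 2-(dimethylamino)ethyl in place of ethynyl on a double-bonded chain carbon bound to a double-bonded chain carbon while the rest of the core of compound 1 stays the same. Among the compounds with values here, no measured pair covers this change, so the expectation is loose. A modest move toward stronger inhibition in this assay is expected, starting from compound 1 at its limit of > 10000 nM in this assay. A result reaching compound 3 at 450 nM is not expected. The estimated change is an at least 2.0-fold lower number from compound 1 to compound 4 (0.30 log units; that floor lies within the scatter) and could prove no more than a limit again. For compound 4 the estimated value is 5000 nM, with an expected range from 1000 nM to 10000 nM.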

Compound 4, half-maximal inhibitory concentration: > 10000 nM
Compound 4: only a limit was reported; the forecaster's own chance of this, stated with the estimate: 50%; at least 2.0-fold (0.30 log units) between middle value and limit.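

Compound 1 and compound 4 both stand at a limit of this assay and not at a number, so no step can be read between them: the limit of > 10000 nM in this assay, at which 2 of the 4 values shown sit.

The compounds shown leave open whether 2-(dimethylamino)ethyl in place of ethynyl changes the value in this assay at all.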